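Acetyl for fluoro on the terminal phenyl: expected inhibition

The compounds below may be only part of what the source reports. "The series", "measured", "known", "first", "only" and "open" are said of these compounds alone.

Measured so far:
compound 1 `Brc1cn2ccnc2c(-c2ccc3ncn(C4CCCCC4)c3c2)n1`: 11.5%
compound 2 `Fc1ccc(-c2cn3ccnc3c(-c3ccc4ncn(C5CCCCC5)c4c3)n2)cc1`: 9.02%

Both numbers come from a functional assay on ACHN cells (Homo sapiens) for inhibition, read by sulforhodamine B assay, with a stated time of 48 h, tested at 10 uM; a lower number here means less inhibition, a higher number more inhibition at the concentration tested (going by the name of the read-out). Compound 2 holds the lower of the two numbers, but its distance to compound 1 lies within the scatter, as the step of a number 2.5 percentage points lower from compound 1 to compound 2 (within the scatter) shows. Compound 3 `CC(=O)c1ccc(-c2cn3ccnc3c(-c3ccc4ncn(C5CCCCC5)c4c3)n2)cc1` differs from compound 2 by acetyl in place of fluoro on an aromatic carbon. Among the compounds with values here, the only measured step that bears on this position is a number 2.5 percentage points lower from compound 1 to compound 2 (within the scatter), which put 4-fluorophenyl in place of bromo without moving the read-out beyond the scatter. Nothing measured separates one substituent on that phenyl from another, so for compound 3 no step beyond the scatter is expected in this assay; the expected step is a number 1 percentage points higher from compound 2 to compound 3 (within the scatter). Compound 3 is therefore estimated at 10% in this assay, with a range from 0% to 25%.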

Compound 3, a percentage reported as inhibition, at one concentration (the size of the read-out at that concentration, not a potency): 4.32%
Beside the measured number, compound 3's estimate is 5.7 percentage points above it; measured number inside the range.
By their numbers in this assay, from the lowest: compounds 3, 2 and 1 (each within the scatter of the next).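

At the position para to a large group on the terminal phenyl, this assay does not separate acetyl from fluoro (a number 4.7 percentage points lower from compound 2 to compound 3 (within the scatter)), so this first change on the phenyl itself, which adds a hydrogen-bond acceptor and a double bond outside aromatic rings, leaves the read-out within the scatter. The wider swap on the same aromatic carbon also stays within the scatter (a number 7.2 percentage points lower from compound 1 to compound 3 (within the scatter)), and so bromo, 4-fluorophenyl and 4-acetylphenyl cannot be told apart in this read-out. Nothing available bears on why these numbers fall where they do.

As far as these compounds go, whether an amine or a carboxylic acid in place of acetyl would give a step beyond the scatter remains open. Also open, from the compounds shown here alone, is whether a longer chain at this position, or any change elsewhere on the shared core, would do so.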